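The source may report more compounds than this note shows. Statements on the series, on what has been measured and on what is new or still open speak of the compounds shown alone.

- Compound 1 `O=C(/C(=C\c1ccc(Br)c(O)c1)S(=O)(=O)c1ccc(Br)cc1)c1ccc(Br)cc1`: 50000 nM
- Compound 2 `O=C(/C(=C\c1ccc(Cl)c([N+](=O)[O-])c1)S(=O)(=O)c1ccc(Br)cc1)c1ccc(Br)cc1`: 10000 nM

In a functional assay on DU-145 cells (Homo sapiens) for inhibition, read by trypan blue exclusion, with a stated time of 96 h (a lower number here means a stronger inhibitor of growth, a higher number a weaker inhibitor of growth), compound 2 holds the lower of the two numbers, at 10000 nM. Compound 3 `O=C(/C(=C\c1ccc(I)cc1)S(=O)(=O)c1ccc(Br)cc1)c1ccc(Br)cc1` differs from it as follows: 4-iodophenyl in place of 4-chloro-3-nitrophenyl on a double-bonded chain carbon bound to a double-bonded chain carbon. This puts 4-iodophenyl in place of 4-chloro-3-nitrophenyl. Going by the values given here, the one measured step changed the same place and was modest: a 5.0-fold lower number from compound 1 to compound 2 (0.70 log units; beyond the scatter). That single step does not settle a direction for this new change, so no step beyond the scatter is expected in this assay, and the expected step is a 1.5-fold higher number from compound 2 to compound 3 (0.18 log units; within the scatter). For compound 3 the estimated value is 15000 nM, with an expected range of 4000 nM to 50000 nM.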

Compound 3, concentration for 50% growth inhibition: 1000 nM
Compound 3: middle estimate off by 15-fold (1.18 log units), on the high side; measured number outside the range, below it.
By their numbers in this assay, from the lowest: compound 3; then compound 2; then compound 1.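

In this assay this place on the double-bonded chain carbon proves far more sensitive than the earlier pair suggested: 4-iodophenyl gives a 10-fold lower number from compound 2 to compound 3 (1.00 log units; beyond the scatter) and, measured against the hydroxyl-bearing ring, a 50-fold lower number from compound 1 to compound 3 (1.70 log units; beyond the scatter). Neither the nitro group nor the hydroxyl is needed for the lowest number of the three, which compound 3 holds. Nothing available explains this drop. From the compounds shown here alone, the change swaps the halogen and removes the nitro group together, so their shares stay open. A 4-chlorophenyl or 4-aminophenyl group at this place would help to separate them.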